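Swapping a pyridine ring for a trifluoroethoxy chain

The compounds below may be only part of what the source reports. "The series", "measured", "known", "first", "only" and "open" are said of these compounds alone.

Of the compounds shown here, three that share a core have been measured in an ADME assay on LLC-PK1 cells (Sus scrofa) for permeability; a higher number here means that the compound crosses the layer faster, a lower number that the compound crosses the layer more slowly. Compound 1 `COc1ccccc1C(=O)NC(=O)Nc1ccc(-c2ccccc2)c(C(C)C)c1` gives 1.2 10^-6 cm/s, compound 3 `COc1ccncc1C(=O)NC(=O)Nc1ccc(-c2ccccc2)c(C(F)(F)F)c1` gives 2.3 10^-6 cm/s, and compound 2 `COc1ccccc1C(=O)NC(=O)Nc1ccc(-c2ccccn2)c(C(F)(F)F)c1` gives 7.4 10^-6 cm/s. Compound 2 thus stands highest of the three, with compound 3 nearest and compound 1 furthest, both gaps beyond the scatter. Compound 4 `COc1ccccc1C(=O)NC(=O)Nc1ccc(OCC(F)(F)F)c(C(F)(F)F)c1` has not yet been measured in this assay. It differs from compound 2 in one place: 2,2,2-trifluoroethoxy in place of pyridin-2-yl on an aromatic carbon. Within the data shown here, no measured pair shows such a change, so the expected step is uncertain; compound 4 is estimated to sit somewhat lower, with a 1.6-fold lower number from compound 2 to compound 4 (0.22 log units; within the scatter) only slightly beyond the scatter. Compound 4 is therefore expected to give about 4.5 10^-6 cm/s, within a range from 2 10^-6 cm/s to 11 10^-6 cm/s.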

Compound 4, apparent permeability: < 1 10^-6 cm/s
Compound 4: a limit, no number; the forecaster's own chance of this, stated with the estimate: 5%; middle value at least 4.5-fold (0.65 log units) from the limit.
By their numbers in this assay, from the lowest: compounds 1 and 3 (each within the scatter of the next); then compound 2. At a limit, below all of these: compound 4.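

Placing 2,2,2-trifluoroethoxy instead of pyridin-2-yl on the aromatic carbon ortho to a trifluoromethyl group gives an at least 7.4-fold lower number from compound 2 to compound 4 (0.86 log units; beyond the scatter) in this assay, so the first measured change at this position moves the read-out clearly, although the count of heavy atoms stays the same. Compound 4 gives < 1 10^-6 cm/s, which is a limit of the assay and not a number. The step is therefore a bound and not an exact size: the limit of < 1 10^-6 cm/s in this assay, at which 1 of the 4 values shown sits.

As far as these compounds go, with only these two groups compared at this position, it remains open where an amine, a carboxylic acid or a longer chain there would fall.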